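The source may hold more compounds than are shown below. What is called first, only, known or untested is meant among the compounds shown, and "the series" means these compounds.

Measured compounds:
compound 1, `Nc1nc(N)c2cc(Sc3ccc(Cl)c(Cl)c3)ccc2n1`, 7.96;
compound 2, `Nc1nc(O)c2c(Sc3ccc4ccccc4c3)cccc2n1`, 6.15;
compound 3, `Nc1nc(N)c2c(Sc3ccc4ccccc4c3)cccc2n1`, 6.92.

These three were tested in an assay for inhibition of Dihydrofolate reductase (Homo sapiens); a higher number here means a more potent compound, by a factor of ten per unit of this negative logarithm, a lower number a less potent compound. Compound 1 gives the highest number of the three, compound 2 the lowest, and both gaps are beyond the usual scatter. Compound 3 and compound 2 differ in a single change, (hydroxy in place of amino on an aromatic carbon), which made a step of a number 0.77 log units lower from compound 3 to compound 2 (beyond the scatter). The cores of compound 1 and compound 3 differ in more than one place, and that difference is not broken down here.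

Compound 4, `Nc1nc(O)c2cc(Sc3ccc(Cl)c(Cl)c3)ccc2n1`, is not yet measured. It comes from compound 1 by hydroxy in place of amino on an aromatic carbon, the same change as from compound 3 to compound 2, at a place described in the same words. The expected step from compound 1 to compound 4 is a number 0.76 log units lower from compound 1 to compound 4 (beyond the scatter), resting on the earlier step of a number 0.77 log units lower from compound 3 to compound 2 (beyond the scatter). Compound 4 is therefore estimated at 7.2, within 6.6 to 7.7.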

Compound 4, logarithm of the reciprocal of the active concentration, log(1/C): 6.92
Compound 4: middle estimate off by 0.28 log units, on the high side; low and high end bracket the measured number.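

In this assay, hydroxy in place of amino on the core of compound 1 made a step of a number 1.04 log units lower from compound 1 to compound 4 (beyond the scatter). The number falls on both cores, and the sizes of the two steps do not differ beyond what measurement scatter allows: the same change on two cores in this assay, a number 0.77 log units lower (beyond the scatter) from compound 3 to compound 2 and a number 1.04 log units lower (beyond the scatter) from compound 1 to compound 4, 0.27 log units apart, within the scatter of two such steps This shows that the change carried over between these two cores, but two cores cannot show that it would do the same on any other core, and the numbers alone do not explain the drop.

The compounds shown leave open how a methyl group, a methoxy group or a longer amine would compare with amino and hydroxy at that place.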